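The compounds below may be only part of what the source reports. "The series", "measured", "known", "first", "only" and "open" are said of these compounds alone.

Of the compounds shown here, three of a shared core have been measured in a functional assay (trachea) with Rattus norvegicus as the target; on this read-out higher numbers stand for higher potency (the scale is a negative logarithm) and lower numbers for lower potency. Compound 1 `CC1(C)C=C(n2ccccc2=O)c2cc(C(=O)c3ccc(O)cc3)ccc2O1` gives 5.87 in this assay, compound 2 `CC1(C)C=C(n2ccccc2=O)c2cc(C(=O)c3ccccc3[N+](=O)[O-])ccc2O1` gives 5.64, and compound 3 `CC1(C)C=C(n2ccccc2=O)c2cc(C(=N)NO)ccc2O1` gives 5.51. Compound 3 thus has the lowest of the three numbers, lying within the scatter of compound 2 but separated from compound 1 by a step that is beyond it: a number 0.36 log units lower from compound 1 to compound 3 (beyond the scatter). The swap between compound 1 and compound 2, a number 0.23 log units lower from compound 1 to compound 2 (within the scatter), was within the scatter.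

Compound 4 `CC1(C)C=C(n2ccccc2=O)c2cc(Br)ccc2O1` is not yet measured. It differs from compound 3 by one bromine atom in place of a group of 4 heavy atoms (1 carbon, 2 nitrogen, 1 oxygen; no ring), on an aromatic carbon. For the measured compounds named here, no measured step replaces a group at this position with a single halogen atom, so the closest guide is the step from compound 1 to compound 3, where a much smaller group in place of an aryl ketone cost a modest amount, while exchange of one aryl for another changed little. Taking a bromine for the amidoxime as a further reduction of the same kind, a small drop or no change beyond the scatter is expected, estimated as a number 0.21 log units lower from compound 3 to compound 4 (within the scatter). Compound 4 is therefore expected to give about 5.3, between 4.7 and 5.9.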

Compound 4, logarithm of the reciprocal of the active concentration, log(1/C): 7.53
Compound 4: middle estimate off by 2.23 log units, on the low side; measured number above the stated range.
By their numbers in this assay, from the lowest: compounds 3, 2 and 1 (each within the scatter of the next, the first and the last beyond it); then compound 4.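

In this assay, the three earlier groups at this position had stayed close together, yet one bromine atom in place of the amidoxime gives a number 2.02 log units higher from compound 3 to compound 4 (beyond the scatter), and bromo in place of (4-hydroxyphenyl)carbonyl gives a number 1.66 log units higher from compound 1 to compound 4 (beyond the scatter). The position on the aromatic carbon therefore tolerates far more change in the read-out than the modest step of a number 0.36 log units lower from compound 1 to compound 3 (beyond the scatter) had suggested, and here the smallest group, with no hydrogen-bond donors or acceptors, stands well clear of the larger ones. No measurement shown here accounts for this rise.

The compounds shown leave open whether the gain belongs to bromine itself or would also come with a chlorine atom, a methyl group or a nitrile at this position. They also leave open how far a single hydrogen there would carry the number.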